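Compound 4: swapping the aryl group of compound 3

The source may report more compounds than this note shows. Statements on the series, on what has been measured and on what is new or still open speak of the compounds shown alone.

compound 1 `COc1ccc(OCCCON2C(N)=NC(N)=NC23CCOCC3)cc1` gives 660 nM
compound 2 `NC1=NC2(CCOCC2)N(OCCCOc2cccc(Cl)c2Cl)C(N)=N1` gives 100 nM
compound 3 `NC1=NC2(CCOCC2)N(OCCCOc2cc(Cl)c(Cl)cc2Cl)C(N)=N1` gives 680 nM

All three numbers come from one test (a functional assay on A549 cells (Homo sapiens) for antiproliferative activity, read by MTT assay, with a stated time of 72 h; a lower number here means a stronger inhibitor, a higher number a weaker inhibitor). Compound 3 (680 nM) shares the high end of this small set with compound 1, and the two cannot be told apart. The remaining gap is clear (a 6.8-fold higher number from compound 2 to compound 3 (0.83 log units; beyond the scatter)).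

Compound 4 `Cc1ccc(OCCCON2C(N)=NC(N)=NC23CCOCC3)cc1` has not been measured yet. It keeps the shared core and the chain, while 4-methylphenyl comes in place of 2,4,5-trichlorophenyl on an oxygen on a saturated carbon (4-methylphenyl in place of 2,4,5-trichlorophenyl on an oxygen on a saturated carbon).

Going by the values given here, no measured step makes exactly this swap. The closest guide is compound 1, which also carries a phenyl group with one 4-substituent, and its exchange for the trichlorophenyl group moved nothing beyond the scatter (a 1.0-fold higher number from compound 1 to compound 3 (0.01 log units; within the scatter)). A warning comes from compound 2, since changing this group can matter (a 6.6-fold lower number from compound 1 to compound 2 (0.82 log units; beyond the scatter)). Still, compound 4 resembles compound 1 more than compound 2 by name of group, so no step beyond the scatter is expected in this assay. The expected step is a 1.5-fold lower number from compound 3 to compound 4 (0.18 log units; within the scatter) as estimated here. Compound 4 is expected at 450 nM with an estimated range of 150 nM to 1300 nM on this estimate.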

Compound 4, half-maximal inhibitory concentration: 1060 nM
Beside the measured number, compound 4's estimate is 2.4-fold (0.37 log units) below it; low and high end bracket the measured number.
By their numbers in this assay, from the lowest: compound 2; then compounds 1, 3 and 4 (each within the scatter of the next).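

In this assay, the 4-methylphenyl group of compound 4 cannot be told apart from the 2,4,5-trichlorophenyl group (a 1.6-fold higher number from compound 3 to compound 4 (0.19 log units; within the scatter)), and methyl cannot be told apart from methoxy on an aromatic carbon (a 1.6-fold higher number from compound 1 to compound 4 (0.21 log units; within the scatter)). Three differently substituted aryl groups, one carrying chlorine and two carrying none, therefore fall together, so the presence of chlorine alone does not set the number: compound 2 is the exception, and its 2,3-dichlorophenyl group now stands apart by the largest step in the set (an 11-fold higher number from compound 2 to compound 4 (1.03 log units; beyond the scatter)). The compounds offer no independent measurement that could explain why this one aryl group differs from the other three.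

From the compounds shown here alone, it remains open whether the lower number of compound 2 depends on having both chlorines in that arrangement, which a plain phenyl group or a phenyl group with a single chlorine would help to test. Also open is whether the same order among these aryl groups would hold with a longer chain joining them to the shared core.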